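Chain Lengthening on Two Cores in an Antiproliferative Series

The source may report more compounds than this note shows. Statements on the series, on what has been measured and on what is new or still open speak of the compounds shown alone.

Compound 1, `CCCNS(=O)(=O)c1ccc(Nc2ncc3c(n2)N(c2ccn(C)n2)C(CC)C(=O)N3C)cc1`, gives 8880 nM in a functional assay on Huh-7 cells (Homo sapiens) for antiproliferative activity, read by CCK-8 assay, with a stated time of 72 h; on this read-out lower numbers stand for stronger inhibition of growth and higher numbers for weaker inhibition of growth.
Compound 2, `CCCCNS(=O)(=O)c1ccc(Nc2ncc3c(n2)N(c2ccn(C)n2)C(CC)C(=O)N3C)cc1`, gives 3750 nM in this assay.
Compound 3, `CCCNC(=O)c1ccc2c(ccn2-c2ncc3c(n2)N(c2ccn(C)n2)C(CC)C(=O)N3C)c1`, gives 7280 nM in this assay.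

Compound 2 differs from compound 1 by methyl in place of hydrogen on a saturated chain carbon, three bonds along the chain from a sulfonamide nitrogen, and this single change produced a 2.4-fold lower number from compound 1 to compound 2 (0.37 log units; beyond the scatter). Compound 3 carries a different core; the difference between the two cores is not broken down here. Its value and that of compound 1 lie within the scatter of each other, so nothing can be said about their order.

Compound 4, `CCCCNC(=O)c1ccc2c(ccn2-c2ncc3c(n2)N(c2ccn(C)n2)C(CC)C(=O)N3C)c1`, is not yet measured. It differs from compound 3 by methyl in place of hydrogen on a saturated chain carbon, three bonds along the chain from an amide-type nitrogen. The place is not the same word for word: in the earlier pair the chain carbon sits three bonds from a sulfonamide nitrogen, here from an amide-type nitrogen, so this is the same kind of change rather than the same change.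

The expectation for compound 4 rests on the step from compound 1 to compound 2, which was a 2.4-fold lower number from compound 1 to compound 2 (0.37 log units; beyond the scatter), and on the value of compound 3, 7280 nM. The step is expected to be a 1.8-fold lower number from compound 3 to compound 4 (0.26 log units; within the scatter), somewhat smaller since the surroundings of the place differ. Compound 4 is therefore estimated at 4000 nM, within 2000 nM to 8000 nM.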

Compound 4, concentration for 50% growth inhibition: 8670 nM
Compound 4: the middle estimate sits 2.2-fold (0.34 log units) below what was measured, outside the stated range (above it).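

In this assay, the same kind of change, propyl to butyl on the core of compound 3, gave a 1.2-fold higher number from compound 3 to compound 4 (0.08 log units; within the scatter), so this step cannot be told apart from no change. Set beside the earlier step, it does not agree with it: the same change on two cores in this assay, a 2.4-fold lower number (0.37 log units; beyond the scatter) from compound 1 to compound 2 and a 1.2-fold higher number (0.08 log units; within the scatter) from compound 3 to compound 4, 2.8-fold (0.45 log units) apart, beyond the scatter of two such steps. Among the compounds shown here, this shows that the lower number seen with the longer chain on the core of compound 1 cannot simply be carried over to the core of compound 3, but it does not show which difference between the two compounds pairs decides the outcome, as each core contributes only a single pair and the cores differ as a whole.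

From the compounds shown here alone, it remains open whether a longer chain such as pentyl would give a step beyond the scatter on either core, or whether the two cores would diverge in the same way. Also open, going by these compounds, is how a chain carrying an amine or a carboxylic acid would behave on each of them.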